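From Pyrimidin-2-yl to 5-Methyl-1,2-oxazol-3-yl on a Sulfonamide Nitrogen

The compounds below may be only part of what the source reports. "The series", "measured", "known", "first", "only" and "open" are said of these compounds alone.

Of the compounds shown here, three built on a shared core have been measured in a functional assay on HCT-116 cells (Homo sapiens) for inhibition, read by sulforhodamine B assay, with a stated time of 2 days (a lower number here means a stronger inhibitor of growth, a higher number a weaker inhibitor of growth), so far. Compound 1 (`CC1=C(C(=O)Nc2ccc(C)cc2)C(c2ccc(O)cc2O)NC(SCc2ccccc2)=N1`) gives 14500 nM as its reading. Compound 2 (`CC1=C(C(=O)Nc2ccc(C)cc2)C(c2ccc(O)cc2O)NC(Nc2ccc([N+](=O)[O-])cc2Cl)=N1`) gives 28200 nM as its reading. Compound 3 (`CC1=C(C(=O)Nc2cccc([N+](=O)[O-])c2)C(c2ccc(O)cc2O)NC(Nc2ccc(S(=O)(=O)Nc3ncccn3)cc2)=N1`) gives 77600 nM as its reading, the highest number of the three and beyond the scatter from both of the others, which makes it the weakest inhibitor of growth among them. Compound 4 (`CC1=C(C(=O)Nc2cccc([N+](=O)[O-])c2)C(c2ccc(O)cc2O)NC(Nc2ccc(S(=O)(=O)Nc3cc(C)on3)cc2)=N1`) has not yet been measured. The change that leads to it from compound 3 is 5-methyl-1,2-oxazol-3-yl in place of pyrimidin-2-yl on a sulfonamide nitrogen and it puts 5-methyl-1,2-oxazol-3-yl in place of pyrimidin-2-yl on a sulfonamide nitrogen.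

Going by the values given here, no measured step touches that place. Among the compounds with values here, the only step available is a 1.9-fold higher number from compound 1 to compound 2 (0.29 log units; within the scatter) and it lies within the scatter, but it concerns a different group and offers only a loose guide. Compound 3 differs from compound 1 and compound 2 in more than one place, so its higher number cannot be assigned to any single group. No step beyond the scatter is therefore expected in this assay in either direction. The estimate is a 1.1-fold lower number from compound 3 to compound 4 (0.04 log units; within the scatter) as an expected step that stays within the scatter. Compound 4 is expected at about 70000 nM with an estimated range from 30000 nM to 150000 nM as its reading.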

Compound 4, concentration for 50% growth inhibition: 16600 nM
Beside the measured number, compound 4's estimate is 4.2-fold (0.62 log units) above it; the whole stated range lies above it.
By their numbers in this assay, from the lowest: compounds 1, 4 and 2 (each within the scatter of the next); then compound 3.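

In this assay, putting 5-methyl-1,2-oxazol-3-yl in place of pyrimidin-2-yl on the sulfonamide nitrogen gives a 4.7-fold lower number from compound 3 to compound 4 (0.67 log units; beyond the scatter), the first step measured at this place and the only single-place step shown that lies beyond the scatter. The result shows that this place responds to which ring sits on the sulfonamide nitrogen, even though the two groups have the same counts of heavy atoms, hydrogen-bond donors and hydrogen-bond acceptors, and neither carries a net charge; what differs is a five-membered aromatic ring in place of a six-membered one, with one oxygen in place of one ring nitrogen. No measurement bearing on either group accompanies this result, and the data give no cause for the step.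

A single pair cannot separate the contributions of ring size, ring hetero atoms and the methyl group, which an unsubstituted 1,2-oxazol-3-yl or a plain phenyl on the same nitrogen would begin to address. From the compounds shown here alone, it also remains open whether the step would carry over to a compound bearing the amide of compound 1, since both members of this pair share a single amide group.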